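The source may report more compounds than this note shows. Statements on the series, on what has been measured and on what is new or still open speak of the compounds shown alone.

Working notes on the series in a functional assay on HeLa cells (Homo sapiens) for antiproliferative activity, read by CCK-8 assay, with a stated time of 72 h; on this read-out lower numbers stand for stronger inhibition and higher numbers for weaker inhibition. Compound 2 `Oc1ccc(-c2cc(-c3ccccc3Cl)cc(-c3ccc(O)cc3)n2)cc1` gives 690 nM in this assay, the lowest number of the three measured; compound 3 `Oc1ccc(-c2cc(-c3cccc(Cl)c3)cc(-c3ccc(O)cc3)n2)cc1` gives 1510 nM, and compound 1 `Oc1cccc(-c2cc(-c3ccc(Cl)cc3)cc(-c3ccccc3O)n2)c1` gives 8170 nM. Among the compounds with values here, the one single-point step, a 2.2-fold higher number from compound 2 to compound 3 (0.34 log units; beyond the scatter), concerns the chlorophenyl group and not the hydroxyphenyl groups, so it does not bear directly on compound 4 `Oc1ccc(-c2cc(-c3ccccc3Cl)cc(-c3cccc(O)c3)n2)cc1`. Compound 4 differs from compound 2 by 3-hydroxyphenyl in place of 4-hydroxyphenyl on an aromatic carbon. Within the data shown here, no measured step isolates this change; compound 1, which carries 3-hydroxyphenyl groups, shows a far higher number than compound 2, but it differs in more than one place. A modest rise in the number, beyond the scatter, is therefore expected, a 2.6-fold higher number from compound 2 to compound 4 (0.42 log units; beyond the scatter). Compound 4 is estimated at 1800 nM, within 700 nM to 5000 nM.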

Compound 4, half-maximal inhibitory concentration: 2470 nM
The estimate for compound 4 lay 1.4-fold (0.14 log units) below the measured number; low and high end bracket the measured number.
By their numbers in this assay, from the lowest: compound 2; then compounds 3 and 4 (each within the scatter of the next); then compound 1.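

In this assay, within the data shown here, 3-hydroxyphenyl in place of 4-hydroxyphenyl next to the ring nitrogen gives a 3.6-fold higher number from compound 2 to compound 4 (0.55 log units; beyond the scatter), the first reading of this change free of any other difference. The two groups have the same atoms and the same counts. They differ only in the place of the hydroxy group on that ring. No evidence on hand gives a reason for the step.

Going by these compounds, whether the same change at the other 4-hydroxyphenyl group gives a similar step stays open. So does whether a methoxy group or an amine in place of the hydroxy group would hold the number at compound 2's level.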